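A few compounds are considered here, and "the series" means these few. Any claim that something is new, unique, unknown or untested is made for them only; others in the source may bear on it.

Measured so far:
Compound 1 `Cc1ccc2c(NCc3ccc(NC(=O)C4CCN(Cc5ccccc5)CC4)cc3)nc(N3CCC(N4CCCC4)CC3)nc2c1`, which in a functional assay on SV5A8 cells (Homo sapiens) for cytotoxicity (on this read-out higher numbers stand for weaker inhibition and lower numbers for stronger inhibition), gives > 8090 nM.
Compound 2 `Cc1ccc2c(NCc3ccc(NC(=O)C4CCN(Cc5ccccc5)CC4)cc3)nc(N(C)CCCN(C)C)nc2c1`, which in this assay gives > 8620 nM.

Both of these values are limits of the assay, not numbers. Compound 1 sits at a limit (the limit of > 8090 nM in this assay, at which 1 of the 2 values shown sits). Compound 2 likewise sits at a limit (the limit of > 8620 nM in this assay, at which 1 of the 2 values shown sits), which is where it stands among the values shown. For the measured compounds named here, the one measured step, a step that the two limits leave unreadable from compound 1 to compound 2, is therefore unreadable in size and direction.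

Compound 3 `CCNc1nc(NCc2ccc(NC(=O)C3CCN(Cc4ccccc4)CC3)cc2)c2ccc(C)cc2n1` is not yet measured in this assay. It differs from compound 2 by ethylamino in place of (3-(dimethylamino)propyl)(methyl)amino on an aromatic carbon. With compound 2 at a limit of > 8620 nM in this assay, at which 1 of the 2 values shown sits, and no readable step to lean on, no direction beyond the scatter can be expected with confidence. Compound 3 is expected to give about 10000 nM, within a range from 3000 nM to 30000 nM. That estimate means an expected step that the limit leaves unreadable from compound 2 to compound 3.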

Compound 3, half-maximal inhibitory concentration: > 2140 nM
Compound 3: a limit, no number; the forecaster's own chance of this, stated with the estimate: 80%; the middle value does not contradict the limit.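

Compound 3, like compound 1 and compound 2, gives only a limit and no number, so the steps to compound 3 cannot be read in size or direction. On these data alone, whether changing this group shifts the read-out in this assay at all stays open.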